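Aryl swap on the thiourea nitrogen in weak cell inhibitors

A few compounds are considered here, and "the series" means these few. Any claim that something is new, unique, unknown or untested is made for them only; others in the source may bear on it.

Working notes on the series. The shared core is seen in compound 1, `Cc1cccc(NC(=S)N/N=C/c2ccc3ccccc3n2)c1`; compound 2 is `COc1cccc(NC(=S)N/N=C/c2ccc3ccccc3n2)c1` and compound 3 is `S=C(N/N=C/c1ccc2ccccc2n1)Nc1ccc(Cl)cc1`. In a functional assay on HT-29 cells (Homo sapiens) for antiproliferative activity, read by sulforhodamine B assay, with a stated time of 72 h (a higher number here means a weaker inhibitor, a lower number a stronger inhibitor), compound 1 returns only a limit, > 100000 nM. In this assay compound 2 gives 82400 nM. Compound 3 gives 97200 nM in this assay, the highest of the two numbers recorded; its nearest neighbour is compound 2, with a 1.2-fold higher number from compound 2 to compound 3 (0.07 log units; within the scatter). The third value recorded is a limit (the limit of > 100000 nM in this assay, at which 1 of the 3 values shown sits). The steps of an at least 1.0-fold lower number from compound 1 to compound 3 (0.01 log units; that floor lies within the scatter) and an at least 1.2-fold lower number from compound 1 to compound 2 (0.08 log units; that floor lies within the scatter) likewise stay inside the scatter.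

Compound 4 is `Cc1ccccc1NC(=S)N/N=C/c1ccc2ccccc2n1`; it carries 2-methylphenyl in place of 4-chlorophenyl on an amide-type nitrogen. The measured steps that bear on this are the aryl exchanges on the same nitrogen, an at least 1.0-fold lower number from compound 1 to compound 3 (0.01 log units; that floor lies within the scatter) and a 1.2-fold higher number from compound 2 to compound 3 (0.07 log units; within the scatter), neither of which left the scatter, so in this assay the expected step is a 1.0-fold higher number from compound 3 to compound 4 (0.01 log units; within the scatter), none beyond the scatter. For compound 4 the estimate in this assay is 100000 nM, in the range 40000 nM to 250000 nM.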

Compound 4, half-maximal inhibitory concentration: 42300 nM
For compound 4 the middle estimate is 2.4-fold (0.37 log units) above the measured one; measured number inside the range.
By their numbers in this assay, from the lowest: compounds 4, 2 and 3 (each within the scatter of the next, the first and the last beyond it). At a limit, above all of these: compound 1.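

Going by these compounds alone, on the amide-type nitrogen whose other neighbour is the thiocarbonyl carbon, 2-methylphenyl in place of 4-chlorophenyl gives a 2.3-fold lower number from compound 3 to compound 4 (0.36 log units; beyond the scatter) in this assay, the first aryl exchange here to leave the scatter. The exchange for 3-methylphenyl gives an at least 2.3-fold lower number from compound 1 to compound 4 (0.37 log units; beyond the scatter), which is only a floor, whereas the exchange for 3-methoxyphenyl gives a 1.9-fold lower number from compound 2 to compound 4 (0.29 log units; within the scatter), so compound 2 goes against any claim that 2-methylphenyl separates from every aryl group shown. Compound 1 stands at a limit and not at a number: the limit of > 100000 nM in this assay, at which 1 of the 4 values shown sits.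

The compounds shown do not tell what sets compound 4 apart from compound 3. Going by these compounds, it also remains open how an aminomethyl group or a carboxylic acid on the aryl ring would behave in this assay.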